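The source may report more compounds than this note shows. Statements on the series, on what has been measured and on what is new or still open speak of the compounds shown alone.

Measured in a functional assay on B16-F10 cells (Mus musculus) for antiproliferative activity, read by MTT assay, with a stated time of 48 h (on this read-out lower numbers stand for stronger inhibition and higher numbers for weaker inhibition), so far:
Compound 1 `CCCCOc1ccc(C(=O)/C=C/c2c(/C=C/c3ccc(OC)cc3)cc(OC)cc2OC)cc1` gives 5.3 ug/mL
Compound 2 `COc1ccc(/C=C/c2cc(OC)cc(OC)c2/C=C/C(=O)c2cccc(Br)c2)cc1` gives 5.1 ug/mL
Compound 3 `COc1ccc(/C=C/c2cc(OC)cc(OC)c2/C=C/C(=O)c2ccc(C(F)(F)F)cc2)cc1` gives 4.3 ug/mL

Compound 3, at 4.3 ug/mL in this assay, cannot be ranked against the other two compounds. The data show a 1.2-fold lower number from compound 1 to compound 3 (0.09 log units; within the scatter) and a 1.2-fold lower number from compound 2 to compound 3 (0.07 log units; within the scatter), so all three values stand together.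

Compound 4 `COc1ccc(/C=C/c2cc(OC)cc(OC)c2/C=C/C(=O)c2ccccc2C)cc1` keeps the shared core and differs from compound 3 in one place: 2-methylphenyl in place of 4-(trifluoromethyl)phenyl on a carbonyl carbon. The change is 2-methylphenyl in place of 4-(trifluoromethyl)phenyl on a carbonyl carbon.

Within the data shown here, the three measured steps all concern the group on this carbonyl carbon, and they are the only evidence that bears on the change. Besides the two steps to compound 3, the series shows a 1.0-fold lower number from compound 1 to compound 2 (0.02 log units; within the scatter). None of the three goes beyond the scatter, whether the group carries butoxy, bromo or trifluoromethyl. Among the measured compounds shown here, no measured compound carries 2-methylphenyl, however, so that group itself remains untested. On this evidence no step beyond the scatter is expected in this assay, and no clear direction can be assigned.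

The estimated change is a 1.1-fold higher number from compound 3 to compound 4 (0.05 log units; within the scatter) overall. For compound 4 the estimated value is 4.8 ug/mL, with an expected range from 2.4 ug/mL to 9.5 ug/mL.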

Compound 4, half-maximal inhibitory concentration: 6.1 ug/mL
Compound 4: the middle estimate sits 1.3-fold (0.10 log units) below what was measured; measured number inside the range.
By their numbers in this assay, from the lowest: compounds 3, 2, 1 and 4 (each within the scatter of the next).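

Among these compounds, compound 4 brings in 2-methylphenyl, a group of carbon only, on the carbonyl carbon, and in this assay the result joins the earlier compounds: the series shows a 1.4-fold higher number from compound 3 to compound 4 (0.15 log units; within the scatter), a 1.2-fold higher number from compound 2 to compound 4 (0.08 log units; within the scatter) and a 1.2-fold higher number from compound 1 to compound 4 (0.06 log units; within the scatter). Even the exchange that takes out the three fluorine atoms and goes from 10 heavy atoms to 7 leaves the two compounds within the scatter of each other, so four different aromatic groups on this carbonyl carbon, carrying butoxy, bromo, trifluoromethyl or methyl, now cannot be told apart on this read-out. Nothing measured alongside these numbers bears on this result.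

The compounds shown leave open whether a phenyl group carrying an amine or a carboxylic acid, or a pyridine ring in its place, would stay within the same scatter on this carbonyl carbon. They also leave open whether changes elsewhere on the shared core, such as replacing a methoxy group with a hydroxyl, would move the number further than any change at this position has.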